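Moving the methyl on the alkyne-linked phenyl ring

This account rests on a few compounds, and the source may have more. Where it says the series, first, only, none or still open, it means among the compounds named here.

Three compounds share one core and differ around it. Compound 1 `Cc1cccc(C#Cc2ccc3c(n2)CCN(C)C3=O)c1` gives 2.9 nM in a functional assay on HEK293 cells for negative allosteric modulation of metabotropic glutamate receptor 5 (Homo sapiens), read by FLIPR and calcium flux; a lower number here means a stronger inhibitor, a higher number a weaker inhibitor. Compound 2 `CC(C)N1CCc2nc(C#Cc3ccccc3)ccc2C1=O` gives 706 nM in this assay, and compound 3 `Cc1ccccc1C#Cc1ccc2c(n1)CCN(C(C)C)C2=O` gives 810 nM. Compound 3 thus stands at the highest of the three numbers; its nearest neighbour is compound 2, and compound 1 lies far lower. For the measured compounds named here, the only single step so far, a 1.1-fold higher number from compound 2 to compound 3 (0.06 log units; within the scatter), came from putting a methyl in place of hydrogen on an aromatic carbon.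

Compound 4 `Cc1cccc(C#Cc2ccc3c(n2)CCN(C(C)C)C3=O)c1` has not yet been measured. It arises from compound 3 by 3-methylphenyl in place of 2-methylphenyl on a triple-bonded carbon. Going by the values given here, compound 1 also carries a 3-methylphenyl at the alkyne, but its core substituent differs from that of compound 3, so no single step joins compound 1 to compound 3 or to compound 4, and the gap between compound 1 and compound 3 can only be noted, not assigned to one change. The methyl itself, judged from the step from compound 2 to compound 3, did little at the other position. A modest move downward in this assay is therefore expected for compound 4, estimated as a 2.3-fold lower number from compound 3 to compound 4 (0.36 log units; beyond the scatter), giving an expected value of 350 nM within a range of 90 nM to 1300 nM.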

Compound 4, half-maximal inhibitory concentration: 4.8 nM
The estimate for compound 4 lay 73-fold (1.86 log units) above the measured number, and the stated range ends above it.
By their numbers in this assay, from the lowest: compounds 1 and 4 (each within the scatter of the next); then compounds 2 and 3 (each within the scatter of the next).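

In this assay, the place of the methyl on the phenyl ring at the triple-bonded carbon proves decisive: 3-methylphenyl in place of 2-methylphenyl, with the same atoms joined differently, gives a 170-fold lower number from compound 3 to compound 4 (2.23 log units; beyond the scatter). The added methyl therefore does not act the same way in both forms, since 3-methylphenyl in place of the unsubstituted phenyl gives a 150-fold lower number from compound 2 to compound 4 (2.17 log units; beyond the scatter), whereas 2-methylphenyl gave only a 1.1-fold higher number from compound 2 to compound 3 (0.06 log units; within the scatter). With 3-methylphenyl in place, isopropyl in place of methyl on the amide-type nitrogen gives a 1.7-fold higher number from compound 1 to compound 4 (0.22 log units; within the scatter), so this change to the ring nitrogen stays within the scatter, and nothing shown here offers an explanation for the effect of moving the methyl.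

The compounds shown leave open whether the large step belongs to methyl alone, or whether 3-chlorophenyl or 3-methoxyphenyl at the same triple-bonded carbon would give a similarly low number. They also leave open how far the amide-type nitrogen tolerates change alongside 3-methylphenyl, for example with a cyclohexyl group or a longer chain such as n-butyl.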